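The compounds below may be only part of what the source reports. "The series", "measured", "known", "first", "only" and "open" are said of these compounds alone.

Working notes on the series. In a functional assay on Hs-578T cells (Homo sapiens) for antiproliferative activity (a lower number here means that less compound is tolerated, a higher number that more compound is tolerated), compound 1 `CC(=O)Nc1ccc(S(=O)(=O)NNC(=O)c2cccnc2Nc2ccc(Cl)cc2)cc1` gives > 100000 nM, which is a limit of the assay and not a number. Compound 2 `O=C(NNS(=O)(=O)c1ccc(F)cc1)c1cccnc1Nc1ccc(Cl)cc1Cl` likewise gives > 100000 nM, again a limit. Going by the values given here, compound 1 therefore stands at the limit of > 100000 nM in this assay, at which 2 of the 2 values shown sit, and no measured step is available. Compound 3 `O=C(NNS(=O)(=O)c1ccc(Cl)cc1Cl)c1cccnc1Nc1ccc(Cl)cc1` differs from compound 1 by 2,4-dichlorophenyl in place of 4-acetamidophenyl on a sulfonyl sulfur. With both known values sitting at the limit, no step beyond the scatter is expected. The expected step is a number no higher from compound 1 to compound 3 (the limit leaves the size open). Compound 3 is estimated at 100000 nM, with a range of 40000 nM to 300000 nM, most likely reported only as a limit.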

Compound 3, concentration lethal to 50% of the cells: 97700 nM
For compound 3 the middle estimate is 1.0-fold (0.01 log units) above the measured one, within the range that was stated.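

In this assay, going by these compounds alone, compound 3 gives 97700 nM, the only value shown that is a number and not a limit. With 2,4-dichlorophenyl in place of 4-acetamidophenyl on a sulfonyl sulfur, the change reads as an at least 1.0-fold lower number from compound 1 to compound 3 (0.01 log units; that floor lies within the scatter). Compound 1 holds only a limit, so this step has a floor but no known size, and most of the series stays at that limit: the limit of > 100000 nM in this assay, at which 2 of the 3 values shown sit.

From the compounds shown here alone, whether an amine or a longer alkyl chain on the sulfonyl sulfur would move the number beyond the scatter remains open.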